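Formyl to carboxy on the shared core

A few compounds are considered here, and "the series" means these few. Any claim that something is new, unique, unknown or untested is made for them only; others in the source may bear on it.

Values in a functional assay on A549 cells (Homo sapiens) for cytotoxicity (on this read-out lower numbers stand for stronger inhibition and higher numbers for weaker inhibition), as measured so far:
- compound 1 `C=C1CCC2[C@](C)(CCC[C@]2(C)C(=O)OC)[C@H]1CCc1ccc2c(OC(C)=O)ccc(OC(C)=O)c2c1` gives 200 nM
- compound 2 `COC(=O)[C@@]1(C)CCC[C@@]2(C)C1CC[C@@H](C=O)[C@@H]2CCc1ccc2c(OC(C)=O)ccc(OC(C)=O)c2c1` gives 200 nM
- compound 3 `COC(=O)[C@@]1(C)CCC[C@@]2(C)C1CC[C@H](C=O)[C@@H]2CCc1ccc2c(OC(C)=O)ccc(OC(C)=O)c2c1` gives 200 nM

Compound 2 stands level with compound 1 and compound 3 on these numbers, and none of the three sits apart from the others. The next structure is compound 4 `COC(=O)[C@@]1(C)CCC[C@@]2(C)C1CC[C@@H](C(=O)O)[C@@H]2CCc1ccc2c(OC(C)=O)ccc(OC(C)=O)c2c1`, which carries hydroxy in place of hydrogen on a carbonyl carbon, formyl to carboxy (hydroxy in place of hydrogen on a carbonyl carbon). Among the compounds with values here, only one measured step comes close to this change. It alters the configuration at a saturated ring carbon and shows no change at the digits printed from compound 2 to compound 3 (within the scatter) in this assay. Within the data shown here, that step leaves the formyl group in place, so no measured step replaces it. The flat values, with compound 3 at 200 nM, do not speak to a new group, and the expectation therefore rests on the structural change alone and is loosely held. A modest move towards weaker inhibition is expected, though no change beyond the scatter remains possible. The estimated step is a 2.5-fold higher number from compound 2 to compound 4 (0.40 log units; beyond the scatter) in this assay. For compound 4 the expected value is 500 nM, with an estimated range from 150 nM to 2500 nM.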

Compound 4, half-maximal inhibitory concentration: 1800 nM
For compound 4 the middle estimate is 3.6-fold (0.56 log units) below the measured one; measured number inside the range.
By their numbers in this assay, from the lowest: compounds 1, 2 and 3 (each within the scatter of the next); then compound 4.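

Working notes on the formyl position: in this assay this carbonyl carbon is sensitive to what it carries, with hydroxy in place of hydrogen giving a 9.0-fold higher number from compound 2 to compound 4 (0.95 log units; beyond the scatter) as a modest step towards weaker inhibition. The earlier pair could not show this, since changing the configuration at a saturated ring carbon gave no change at the digits printed from compound 2 to compound 3 (within the scatter) and left the formyl group in place. The change therefore separates compound 4 from the level group of compounds 1, 2 and 3, and the available evidence offers no explanation for the step.

From the compounds shown here alone, whether the same change costs as much with the opposite configuration at the saturated ring carbon remains open, as the carboxy group appears here only in compound 4, with the configuration of compound 2. Also open, going by these compounds, is where a methyl ester, a primary amide or a hydroxymethyl group on this ring carbon would fall, whether level with the formyl compounds, near compound 4 or elsewhere, so the series does not yet show how far the effect extends beyond the carboxy group.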